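Oxazolidinone in place of hydantoin on a shared pyridinone core

The source may report more compounds than this note shows. Statements on the series, on what has been measured and on what is new or still open speak of the compounds shown alone.

Measured so far:
compound 1 `CN1C(=O)OC(C)(c2ccc(-c3ccc4ccccc4c3)[nH]c2=O)C1=O` 501 nM
compound 2 `CC1(c2ccc(-c3ccc4ccccc4c3)[nH]c2=O)NC(=O)NC1=O` 316 nM

Both were tested in a functional assay on CHO cells for antagonist activity at prostaglandin E2 receptor EP3 subtype (Homo sapiens), read by FLIPR, with a stated time of 1 h; on this read-out lower numbers stand for stronger inhibition and higher numbers for weaker inhibition. In this assay compound 1 gives 501 nM and compound 2 gives 316 nM; compound 2 has the lower of the two numbers, but the gap to compound 1 lies within the usual scatter, so the two cannot be told apart.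

Compound 3 `CC1(c2ccc(-c3ccc4ccccc4c3)[nH]c2=O)CNC(=O)O1` has not yet been measured. It differs from compound 2 in one place: 5-methyl-2-oxo-1,3-oxazolidin-5-yl in place of 4-methyl-2,5-dioxoimidazolidin-4-yl on an aromatic carbon. The ring that enters carries one carbonyl fewer and one hydrogen-bond donor fewer than the ring that leaves. Within the data shown here, no measured pair in this set shows what such a change does, so there is no step to lean on.

Among the measured compounds shown here, with only two compounds, both close together, the estimate for compound 3 is that it stays near them, expected at 500 nM with a range from 150 nM to 2000 nM, a step of a 1.6-fold higher number from compound 2 to compound 3 (0.20 log units; within the scatter) that is expected to be a modest weakening at most.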

Compound 3, inhibition constant: 79.4 nM
Estimate against measurement, compound 3: 6.3-fold (0.80 log units) above; measured number outside the range, below it.
By their numbers in this assay, from the lowest: compound 3; then compounds 2 and 1 (each within the scatter of the next).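

In this assay, putting 5-methyl-2-oxo-1,3-oxazolidin-5-yl in place of 4-methyl-2,5-dioxoimidazolidin-4-yl gives a 4.0-fold lower number from compound 2 to compound 3 (0.60 log units; beyond the scatter), which shows that the number responds to which ring sits at this position on the shared core. The entering ring has one carbonyl fewer and one hydrogen-bond donor fewer, so the stronger inhibition does not depend on keeping either of them, although the two losses come together in this single change and cannot be separated. Nothing available explains why this swap lowers the number.

From the compounds shown here alone, it remains open whether an ethyl group in place of the methyl on the entering ring would keep this lower number. The effect of a methyl group on that ring's nitrogen, or of an open-chain amide at the same place, is also unknown.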